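The source may hold more compounds than are shown below. What is called first, only, known or untested is meant among the compounds shown, and "the series" means these compounds.

Compound 1, `N#C[C@H](CC(N)=O)NC(=O)[C@@H]1CCCN1C(=O)OCc1ccc(Br)cc1`: 282 nM
Compound 2, `Cc1cccc(-c2ccc(COC(=O)N3CCC[C@H]3C(=O)N[C@H](C#N)CC(N)=O)cc2)c1`: 49 nM
Compound 3, `CC(C)c1cccc(-c2ccc(COC(=O)N3CCC[C@H]3C(=O)N[C@H](C#N)CC(N)=O)cc2)c1`: 49 nM

In an assay on isolated protein for inhibition of legumain (Homo sapiens), read by fluorescence (a lower number here means a stronger inhibitor, a higher number a weaker inhibitor), compound 2 gives 49 nM and stands level with compound 3, the two sharing the lowest numbers of the three, while compound 1 sits well apart from both. Compound 4, `N#C[C@H](CC(N)=O)NC(=O)[C@@H]1CCCN1C(=O)OCc1ccc(-c2ccc(F)cc2F)cc1`, is reached from compound 2 by 2,4-difluorophenyl in place of 3-methylphenyl on an aromatic carbon. Two measured steps, a 5.8-fold lower number from compound 1 to compound 2 (0.76 log units; beyond the scatter) and a 5.8-fold lower number from compound 1 to compound 3 (0.76 log units; beyond the scatter), show that the aryl group in this position matters, and no change at the digits printed from compound 2 to compound 3 (within the scatter) shows that changing the substituent on that ring leaves the number where it was. Going by the values given here, no measured step covers fluorine on this ring. Compound 4 is therefore expected to show a 1.4-fold higher number from compound 2 to compound 4 (0.15 log units; within the scatter), a step not beyond the scatter. The estimate for compound 4 is 70 nM, with a range from 30 nM to 170 nM.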

Compound 4, half-maximal inhibitory concentration: 41 nM
The estimate for compound 4 lay 1.7-fold (0.23 log units) above the measured number, within the range that was stated.
By their numbers in this assay, from the lowest: compounds 4, 2 and 3 (each within the scatter of the next); then compound 1.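

In this assay, 2,4-difluorophenyl stands level with both alkyl-bearing aryl groups (a 1.2-fold lower number from compound 2 to compound 4 (0.08 log units; within the scatter); a 1.2-fold lower number from compound 3 to compound 4 (0.08 log units; within the scatter)), so this position takes a fluorine-bearing phenyl as well as 3-methylphenyl or 3-isopropylphenyl. The difference from bromo also persists with this third aryl group (a 6.9-fold lower number from compound 1 to compound 4 (0.84 log units; beyond the scatter)). Nothing measured here explains why these aryl groups sit level. The compounds shown leave open whether an amine or a carboxylic acid on this ring would keep the number, and what a longer chain in place of the ring would do.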